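The compounds below may be only part of what the source reports. "The series", "measured", "known", "first", "only" and "open" are said of these compounds alone.

Among the compounds with values here, compound 1 `CC(C)CCn1cnc2c(Nc3ccc(Cl)cc3)nc(N[C@H]3CC[C@H](N)CC3)nc21` is one of three compounds measured in a functional assay on HCC827 cells (Homo sapiens) for inhibition, read by fluorescence, with a stated time of 72 h (a higher number here means a weaker inhibitor of growth, a lower number a stronger inhibitor of growth), where compound 1 gives 10200 nM. Compound 2 `CCCCCCn1cnc2c(Nc3ccc(Cl)cc3)nc(N[C@H]3CC[C@H](N)CC3)nc21` carries a hexyl chain on the same nitrogen and gives 11700 nM in this assay, while compound 3 `N[C@H]1CC[C@H](Nc2nc(Nc3ccc(Cl)cc3)c3ncn(C4CCCCC4)c3n2)CC1` carries a cyclohexyl group there and gives 9100 nM. Compound 1 sits second highest of the three numbers, with compound 3 nearest: the step of a 1.1-fold lower number from compound 1 to compound 3 (0.05 log units; within the scatter) and the step of a 1.1-fold higher number from compound 1 to compound 2 (0.06 log units; within the scatter) both lie within the scatter, as does the step of a 1.3-fold lower number from compound 2 to compound 3 (0.11 log units; within the scatter). The three values are thus indistinguishable from one another.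

Compound 4 `CC(C)CCn1cnc2c(NCc3cccc(Cl)c3)nc(N[C@H]3CC[C@H](N)CC3)nc21` differs from compound 1 at the other nitrogen of the shared core: 3-chlorobenzyl in place of 4-chlorophenyl on a nitrogen on an aromatic ring. Within the data shown here, none of the measured steps touches this position; all three vary the group on the aromatic nitrogen bearing the isopentyl, hexyl or cyclohexyl chain and leave the 4-chlorophenyl unchanged. Among the measured compounds shown here, the measured data therefore give no direct guide to the size or direction of this change, only that the three measured compounds cluster tightly. Compound 4 is accordingly expected to fall near that cluster, with a wide range to cover the unknown. The estimated step is a 1.2-fold higher number from compound 1 to compound 4 (0.07 log units; within the scatter). The estimated value for compound 4 in this assay is 12000 nM, between 4000 nM and 36000 nM.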

Compound 4, concentration for 50% growth inhibition: 16700 nM
Compound 4: middle estimate off by 1.4-fold (0.14 log units), on the low side; the range from low to high includes it.
By their numbers in this assay, from the lowest: compounds 3, 1, 2 and 4 (each within the scatter of the next).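

Within the data shown here, this is the first measured step at the nitrogen that carries the 4-chlorophenyl in compound 1, and it shows that this group can be exchanged as well as the chain on the other nitrogen. In this assay, putting 3-chlorobenzyl in place of 4-chlorophenyl gives a 1.6-fold higher number from compound 1 to compound 4 (0.21 log units; within the scatter), so even a swap that alters both the placing of the chlorine on the ring and the link from the ring to the nitrogen stays within the scatter, as the three earlier steps on the chain do. Nothing in the information at hand accounts for the size of this step.

The two alterations arrive together in compound 4, so the compounds shown cannot separate them; a 4-chlorobenzyl or a 3-chlorophenyl group at this nitrogen would do so. Also open, on these data alone, is whether any group here can move the number beyond the scatter, for instance a plain phenyl without chlorine, or a ring bearing a carboxylic acid or an amine.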